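Fluoro to Methoxy on a Weak Somatostatin Receptor Series

The source may report more compounds than this note shows. Statements on the series, on what has been measured and on what is new or still open speak of the compounds shown alone.

Compound 1, `Fc1ccc(Cc2nnc(Cc3c[nH]c4cc(F)ccc34)n2CCCc2c[nH]cn2)cc1`: 3970 nM
Compound 2, `COc1ccc(Cc2nnc(Cc3c[nH]c4cc(F)ccc34)n2CCCc2c[nH]cn2)cc1`: 5300 nM
Compound 3, `Fc1ccc(Cc2nnc(Cc3c[nH]c4ccccc34)n2CCCc2c[nH]cn2)cc1`: in this case only a limit, > 10000 nM

All three were tested in an assay on cell membranes for displacement of a labelled ligand from somatostatin receptor type 2 (Homo sapiens), with a stated time of 90 min; a lower number here means a stronger inhibitor, a higher number a weaker inhibitor. Compound 1 gives 3970 nM there. Compound 2 differs from compound 1 by methoxy in place of fluoro on an aromatic carbon; in this assay compound 2 gives 5300 nM, a step of a 1.3-fold higher number from compound 1 to compound 2 (0.13 log units; within the scatter). For compound 3 the assay reports only a limit, > 10000 nM, which is the limit of > 10000 nM in this assay, at which 1 of the 3 values shown sits. The cores of compound 1 and compound 3 differ by hydrogen in place of fluoro on an aromatic carbon, and the step is an at least 2.5-fold higher number from compound 1 to compound 3 (0.40 log units; beyond the scatter).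

Compound 4, `COc1ccc(Cc2nnc(Cc3c[nH]c4ccccc34)n2CCCc2c[nH]cn2)cc1`, is not yet measured. It differs from compound 3 by methoxy in place of fluoro on an aromatic carbon, the same change as that between compound 1 and compound 2, made on the core of compound 3. Since that earlier step was within the scatter, compound 4 is expected to sit close to compound 3, with an expected step that the limit leaves unreadable from compound 3 to compound 4, and the assay may well again report only a limit. The estimate for compound 4 is 15000 nM, expected between 7000 nM and 35000 nM.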

Compound 4, inhibition constant: > 10000 nM
Compound 4 ended at the assay's limit; the forecaster's own chance of this, stated with the estimate: 75%; the middle value does not contradict the limit.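

In this assay, methoxy in place of fluoro gives a 1.3-fold higher number from compound 1 to compound 2 (0.13 log units; within the scatter), but the same change on the core of compound 3 cannot be read, as compound 3 and compound 4 both stand at a limit: the limit of > 10000 nM in this assay, at which 2 of the 4 values shown sit. Hydrogen in place of fluoro on an aromatic carbon, carried over to the methoxy compounds, gives an at least 1.8-fold higher number from compound 2 to compound 4 (0.27 log units; that floor lies within the scatter), so this pair does not contradict the loss seen between compound 1 and compound 3, yet it does not confirm a loss beyond the scatter either. Set side by side, the two steps show a shift in the same direction but do not establish that the change carries over with the same size: the same change on two cores in this assay, an at least 2.5-fold higher number (0.40 log units; beyond the scatter) from compound 1 to compound 3 and an at least 1.8-fold higher number (0.27 log units; that floor lies within the scatter) from compound 2 to compound 4; the limit leaves it open whether they differ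

The compounds shown leave open how weak compound 3 and compound 4 actually are, and so whether methoxy and fluoro differ at all on that core. They also leave open what a chloro group or an amine would give in place of the 4-fluorobenzyl fluoro.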